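Nitro in place of bromo on the shared core

The source may report more compounds than this note shows. Statements on the series, on what has been measured and on what is new or still open speak of the compounds shown alone.

Two compounds of the series carry a measured number. Compound 1 `Cc1ccc2c(c1)/C(=N/NC(=S)N1CCN(c3ccccc3)CC1)C(=O)N2` gives 14900 nM in a functional assay on MCF7 cells (Homo sapiens) for inhibition, read by MTT assay, with a stated time of 72 h; on this read-out higher numbers stand for weaker inhibition and lower numbers for stronger inhibition. In this assay compound 2 `O=C1Nc2ccc(Br)cc2/C1=N/NC(=S)N1CCN(c2ccccc2)CC1` gives 20500 nM. Among the measured compounds shown here, the one step between them is a 1.4-fold higher number from compound 1 to compound 2 (0.14 log units; within the scatter), bromo in place of methyl on an aromatic carbon. Compound 2 thus holds the higher of the two numbers, but as that gap lies within the scatter no order between compound 1 and compound 2 is claimed.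

Compound 3 `O=C1Nc2ccc([N+](=O)[O-])cc2/C1=N/NC(=S)N1CCN(c2ccccc2)CC1` has not yet been measured in this assay. It differs from compound 2 by nitro in place of bromo on an aromatic carbon. No measured step exchanges bromo for nitro, so nothing measured bears on this change directly; the only step shown, a 1.4-fold higher number from compound 1 to compound 2 (0.14 log units; within the scatter), tells merely that one swap of the substituent at this place left the number within the scatter. Compound 3 is therefore expected to show a step of a 1.0-fold lower number from compound 2 to compound 3 (0.01 log units; within the scatter), nothing beyond the scatter. For compound 3 a value of 20000 nM is estimated, with a range from 8000 nM to 50000 nM.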

Compound 3, half-maximal inhibitory concentration: 23300 nM
Compound 3: the middle estimate sits 1.2-fold (0.07 log units) below what was measured; the measured number falls inside the stated range.
By their numbers in this assay, from the lowest: compounds 1, 2 and 3 (each within the scatter of the next).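

Notes on this position: in this assay the exchange of bromo for nitro gives a 1.1-fold higher number from compound 2 to compound 3 (0.06 log units; within the scatter) and thus adds a second substituent swap at this aromatic carbon with no step beyond the scatter. Nitro brings more heavy atoms than bromo, along with hydrogen-bond acceptors, and this difference in the group entering the six-membered aromatic ring is not matched by any readable shift in the number. The direct exchange of methyl for nitro, read as a 1.6-fold higher number from compound 1 to compound 3 (0.19 log units; within the scatter) in the same assay, also stays within the scatter, so methyl, bromo and nitro cannot be told apart here, and no measurement at hand offers an account of this insensitivity.

It stays open whether any group at this aromatic carbon can move the number beyond the scatter, in either direction; an amine, a carboxylic acid or a longer chain such as butyl would probe a different kind of substituent from the three shown. On these data alone, all three compounds share the rest of the structure, so the effect of a change elsewhere, for instance replacing the phenyl group, also remains open.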